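Changing One Aromatic Ring: What to Expect for Compound 3

The source may report more compounds than this note shows. Statements on the series, on what has been measured and on what is new or still open speak of the compounds shown alone.

Compound 1, `COc1cc(NC(=O)Nc2cc(Nc3ccc(F)c(Cl)c3)ncn2)cc(OC)c1`, gives 53.1% in a functional assay on HCC827 cells (Homo sapiens) for inhibition, read by MTT assay, with a stated time of 48 h, tested at 10 uM; a higher number here means more inhibition at the concentration tested (going by the name of the read-out), a lower number less inhibition.
Compound 2, `COc1cc(NC(=O)Nc2cc(Nc3ccc(Br)cc3OC)ncn2)cc(OC)c1`, gives 57.7% in this assay.

Compound 2 sits side by side with compound 1: the step of a number 4.6 percentage points higher from compound 1 to compound 2 (within the scatter) is within the usual scatter, so the two numbers cannot be told apart. Compound 3, `COc1cc(NC(=O)Nc2cc(Nc3cc(C)cc(F)c3)ncn2)cc(OC)c1`, differs from compound 2 in a single place: 3-fluoro-5-methylphenyl in place of 4-bromo-2-methoxyphenyl on a nitrogen on an aromatic ring. Going by the values given here, the only measured step that bears on this place is a number 4.6 percentage points higher from compound 1 to compound 2 (within the scatter), where the same aromatic ring was exchanged and the read-out barely moved. With nothing else to go on, the same kind of exchange here is expected to give no step beyond the scatter, that is a number 3.7 percentage points lower from compound 2 to compound 3 (within the scatter). Compound 3 is therefore estimated to give about 54% in this assay, most likely between 40% and 68%.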

Compound 3, a percentage reported as inhibition, at one concentration (the size of the read-out at that concentration, not a potency): 62.1%
For compound 3 the middle estimate is 8.1 percentage points below the measured one; the range from low to high includes it.
By their numbers in this assay, from the lowest: compounds 1, 2 and 3 (each within the scatter of the next).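

Going by these compounds alone, with compound 3, three different substituted phenyl groups have now sat on this nitrogen, and in this assay the steps of a number 4.4 percentage points higher from compound 2 to compound 3 (within the scatter) and a number 9 percentage points higher from compound 1 to compound 3 (within the scatter) leave no pair of them separated beyond the scatter. The exchange replaces the bromine and methoxy group of compound 2 with a fluorine and a methyl group, so neither the bromine nor the methoxy group is required for a read-out at this level among these compounds. Nothing at hand explains why these three rings read alike.

On these data alone, all three rings on this nitrogen carry a halogen, so it remains open how the read-out would respond to an unsubstituted phenyl ring, a dimethylamino group or a carboxylic acid there. Each number also comes from a single concentration, which leaves the potency of these compounds unknown.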